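This account rests on a few compounds, and the source may have more. Where it says the series, first, only, none or still open, it means among the compounds named here.

Compound 3 `Clc1ccc(-c2cc(-c3ccoc3)cc(-c3ccccn3)n2)s1` belongs to a small set of three compounds in which one group on the shared core is varied. In an assay on isolated protein for inhibition of DNA topoisomerase 1 (Homo sapiens), with a stated time of 30 min, tested at 100 uM (a lower number here means less inhibition, a higher number more inhibition at the concentration tested (going by the name of the read-out)), compound 3 gives 3.1%. Its neighbours are compound 1 `Clc1ccc(-c2cc(-c3ccoc3)cc(-c3ccco3)n2)s1`, which gives 9.6% in this assay, and compound 2 `Clc1ccc(-c2cc(-c3ccoc3)cc(-c3ccc(Cl)s3)n2)cc1`, which gives 2.3%. Going by the values given here, the three numbers lie close together: the step of a number 0.8 percentage points higher from compound 2 to compound 3 (within the scatter) and the step of a number 6.5 percentage points lower from compound 1 to compound 3 (within the scatter) are both within the scatter, as is the step of a number 7.3 percentage points lower from compound 1 to compound 2 (within the scatter), so no compound of the three can be said to give a higher or lower number than another in this assay on these numbers.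

Compound 4 `Clc1ccc(-c2cc(-c3ccoc3)cc(-c3cccnc3)n2)s1` differs from compound 3 in one place: pyridin-3-yl in place of pyridin-2-yl on an aromatic carbon. Among the compounds with values here, no measured step exchanges one pyridyl group for another, so the only guidance comes from the three steps at the same position, each of which stayed within the scatter when the group was changed between furan-2-yl, 4-chlorophenyl and pyridin-2-yl. Nothing in these data suggests that this position moves this assay, and compound 4 is therefore expected to show a step of a number 0.9 percentage points higher from compound 3 to compound 4 (within the scatter), that is, no step beyond the scatter. For compound 4 the estimate in this assay is 4%, expected to fall between 0% and 14%.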

Compound 4, a percentage reported as inhibition, at one concentration (the size of the read-out at that concentration, not a potency): 2%
Compound 4: middle estimate off by 2 percentage points, on the high side; measured number inside the range.
By their numbers in this assay, from the lowest: compounds 4, 2, 3 and 1 (each within the scatter of the next).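

The exchange of pyridin-2-yl for pyridin-3-yl, which joins the same atoms differently, gives in this assay a step of a number 1.1 percentage points lower from compound 3 to compound 4 (within the scatter) and so adds a change within one ring type to the earlier exchanges between different groups. The wider comparisons read the same way, with a step of a number 0.3 percentage points lower from compound 2 to compound 4 (within the scatter) for the exchange from 4-chlorophenyl and a step of a number 7.6 percentage points lower from compound 1 to compound 4 (within the scatter) for the exchange from furan-2-yl. Across these four compounds, therefore, neither the choice of group at this position nor the place of the nitrogen in the pyridine ring separates any compound from the others beyond the scatter, and no other data bear on this result.

Going by these compounds, it remains open whether a group of another kind at this position, such as an amine, a carboxylic acid or a longer alkyl chain, would give a number beyond the scatter from these four. On these data alone, it also remains open whether replacing the furan-3-yl group, which stays the same in all four compounds, would move the number in this test.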